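Trimming the Alkynyl Chain From a Weak Antiproliferative

A few compounds are considered here, and "the series" means these few. Any claim that something is new, unique, unknown or untested is made for them only; others in the source may bear on it.

Compound 1 `O=c1nc2oc(CCCCl)c(C#CCCCCl)c2cn1Cc1cn(-c2ccc(Cl)cc2)nn1` gives 72500 nM in a functional assay on HepG2 cells (Homo sapiens) for antiproliferative activity, read by MTT assay, with a stated time of 72 h; on this read-out higher numbers stand for weaker inhibition and lower numbers for stronger inhibition.
Compound 2 `CCCCCc1ccc(C#Cc2c(-c3ccc(CCCCC)cc3)oc3nc(=O)n(Cc4cn(-c5ccccc5F)nn4)cc23)cc1` gives 72500 nM in this assay.

Both measured compounds show weak inhibition of the liver cancer cells, and compound 1 stands level with compound 2 at the digits shown, a difference within the usual scatter, so neither can be called the stronger of the two. Compound 3 `O=c1nc2oc(CCCCl)cc2cn1Cc1cn(-c2ccc(Cl)cc2)nn1` has not yet been measured. It is the analogue of compound 1 in which (hydrogen in place of 5-chloropent-1-yn-1-yl on an aromatic carbon). Going by the values given here, no step between two measured compounds is available, so there is no measured guide to how much this particular change should matter. With both measured compounds sitting at the same weak level, the step of no change at the digits printed from compound 1 to compound 3 (within the scatter) is expected to be none beyond the scatter. Compound 3 is therefore estimated at 72500 nM, with a likely range from 30000 nM to 120000 nM.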

Compound 3, half-maximal inhibitory concentration: 89800 nM
For compound 3 the middle estimate is 1.2-fold (0.09 log units) below the measured one; low and high end bracket the measured number.
By their numbers in this assay, from the lowest: compounds 1, 2 and 3 (each within the scatter of the next).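

In this assay, replacing the 5-chloropent-1-yn-1-yl group with hydrogen on the aromatic carbon gives a 1.2-fold higher number from compound 1 to compound 3 (0.09 log units; within the scatter). Going by these compounds alone, this is the first measured step at this position, and it shows that the whole chain, with its triple bond and terminal chlorine, can leave the core of compound 1 without a change in the read-out beyond the scatter, so this chain adds no measurable inhibition of these cells. No measurement bearing on why the step is so small is available.

As far as these compounds go, whether an amine or a carboxylic acid on this aromatic carbon would shift the number beyond the scatter remains open. From the compounds shown here alone, it is also open whether the 5-chloropent-1-yn-1-yl group would count for as little in a more strongly inhibiting compound, as all the compounds shown sit at a weak level.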